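Urea series: chloro in place of ethoxycarbonyl on the aromatic ring

The source may report more compounds than this note shows. Statements on the series, on what has been measured and on what is new or still open speak of the compounds shown alone.

For the measured compounds named here, compound 2 `CCOC(=O)c1cccc(NC(=O)N[C@H](C)c2ccccc2)c1` gives 88% in an ADME assay on the whole organism with Oryza sativa as the target, tested at 10 uM (on this read-out lower numbers stand for a stronger effect and higher numbers for a weaker effect at the one concentration tested), the second highest of the three numbers measured so far. Its nearest neighbour is compound 3 `CCOC(=O)c1cccc(NC(=O)N[C@@H](C)c2ccccc2)c1`, which gives 96% in this assay; the step of a number 8 percentage points higher from compound 2 to compound 3 (within the scatter) rests on (the fact that compounds 2 and 3 differ only in the configuration as drawn), and the two values cannot be told apart. The furthest is compound 1 `C[C@@H](NC(=O)Nc1cccc(C(F)(F)F)c1)c1ccccc1`, which gives 70% in this assay, so that a number 18 percentage points higher from compound 1 to compound 2 (beyond the scatter).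

Compound 4 `C[C@@H](NC(=O)Nc1cccc(Cl)c1)c1ccccc1` is not yet measured. It differs from compound 2 in one place: chloro in place of ethoxycarbonyl on an aromatic carbon. Going by the values given here, the only measured step that bears on this change is a number 18 percentage points higher from compound 1 to compound 2 (beyond the scatter), the one step in which the group on that aromatic carbon was exchanged; the change in configuration, a number 8 percentage points higher from compound 2 to compound 3 (within the scatter), stays within the scatter and carries no information on the substituent. Compound 4 again carries a single small group in place of ethoxycarbonyl, so a step back towards the value of compound 1 is expected, of about the size seen before and in the opposite direction, that is a number 14 percentage points lower from compound 2 to compound 4 (beyond the scatter). For compound 4 the expected value in this assay is therefore 74%, with a range from 58% to 90%.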

Compound 4, a percentage reported as activity, at one concentration (the size of the read-out at that concentration, not a potency): 83%
Beside the measured number, compound 4's estimate is 9 percentage points below it, within the range that was stated.
By their numbers in this assay, from the lowest: compound 1; then compounds 4, 2 and 3 (each within the scatter of the next, the first and the last beyond it).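

In this assay, the chloro and ethoxycarbonyl compounds cannot be told apart, with a number 5 percentage points lower from compound 2 to compound 4 (within the scatter), even though ethoxycarbonyl has 5 heavy atoms and 2 hydrogen-bond acceptors and chloro has 1 heavy atom and 0 acceptors. Chloro and trifluoromethyl do separate on this aromatic carbon, with a number 13 percentage points higher from compound 1 to compound 4 (beyond the scatter), so among these three groups only trifluoromethyl stands apart, and a single small group in this place does not by itself give the value of compound 1. The only available finding concerns configuration and offers no explanation of how these groups compare.

Open, on these data alone, is where an amine or a carboxylic acid on this aromatic carbon would fall relative to trifluoromethyl and chloro. Also open, as far as these compounds go, is whether the two configurations at the saturated chain carbon remain indistinguishable with chloro in place of ethoxycarbonyl.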